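Swapping the acetyl for a vinyl on the outer ring

A few compounds are considered here, and "the series" means these few. Any claim that something is new, unique, unknown or untested is made for them only; others in the source may bear on it.

Measured so far:
compound 1, `COc1cc(-c2ccnc3cc(-c4ccc(C)cc4)nn23)cc(OC)c1OC`: 21 nM
compound 2, `COc1cc(-c2ccnc3cc(-c4ccc(C(C)=O)cc4)nn23)cc(OC)c1OC`: 3930 nM
compound 3, `COc1cc(-c2ccnc3cc(-c4ccc(F)cc4)nn23)cc(OC)c1OC`: 4540 nM

Compound 2 stands second highest of the three numbers in a functional assay on B16-F0 cells (Mus musculus) for inhibition, read by CCK-8 assay, with a stated time of 48 h; a lower number here means a stronger inhibitor, a higher number a weaker inhibitor. Its nearest neighbour is compound 3, at a 1.2-fold higher number from compound 2 to compound 3 (0.06 log units; within the scatter). Its furthest is compound 1, at a 190-fold higher number from compound 1 to compound 2 (2.27 log units; beyond the scatter), a step seen the other way round.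

Compound 4, `C=Cc1ccc(-c2cc3nccc(-c4cc(OC)c(OC)c(OC)c4)n3n2)cc1`, is the unmeasured compound. It differs from compound 2 at one spot: vinyl in place of acetyl on an aromatic carbon. Of the measured steps, the one that bears most directly on this is the change from compound 1 to compound 2, where acetyl entered in place of methyl and the number rose sharply. The other step, a 220-fold higher number from compound 1 to compound 3 (2.33 log units; beyond the scatter), shows a similar rise for a fluoro. Nothing measured pairs a vinyl against any of these groups.

Going from acetyl to vinyl removes the carbonyl oxygen and leaves a group made of carbon only. Compound 4 is therefore expected to move part of the way back toward compound 1, with the step of a 9.8-fold lower number from compound 2 to compound 4 (0.99 log units; beyond the scatter) estimated to run downward by a substantial amount. Compound 4 is expected to give about 400 nM, within a range of 40 nM to 4000 nM.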

Compound 4, half-maximal inhibitory concentration: 788 nM
For compound 4 the middle estimate is 2.0-fold (0.29 log units) below the measured one; the measured number falls inside the stated range.
By their numbers in this assay, from the lowest: compound 1; then compound 4; then compounds 2 and 3 (each within the scatter of the next).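

In this assay the 4-vinylphenyl group of compound 4 recovers part of what the 4-acetylphenyl group of compound 2 gives up (a 5.0-fold lower number from compound 2 to compound 4 (0.70 log units; beyond the scatter)), and compound 4 stands clear of the fluoro compound as well (a 5.8-fold lower number from compound 3 to compound 4 (0.76 log units; beyond the scatter)). The recovery is only partial (a 38-fold higher number from compound 1 to compound 4 (1.57 log units; beyond the scatter)), so this position does not simply divide methyl from every other group: the vinyl compound occupies a level of its own, with compound 1 on one side and compounds 2 and 3, which lie within the scatter of each other, on the other. The change from acetyl to vinyl removes the oxygen and its hydrogen-bond acceptor while keeping a double bond outside the aromatic rings, but no measurement here explains why the number moves as it does.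

On these data alone, whether ethyl, the saturated counterpart of vinyl, would fall nearer to compound 1 or to compound 4 remains open. Also open, as far as these compounds go, is where a group such as an amine, a hydroxyl or a methoxy would fall at this position, and whether this order would hold in any other cell line.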